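Shortening a phenyl-capped chain on a lactam-linked lactone series

This account rests on a few compounds, and the source may have more. Where it says the series, first, only, none or still open, it means among the compounds named here.

Measured compounds:
compound 1, `O=C(CCCCCc1ccccc1)N[C@H]1CCOC1=O`: > 100000 nM
compound 2, `O=C(CCCCCCCCCc1ccccc1)CC(=O)N[C@H]1CCOC1=O`: 16000 nM
compound 3, `O=C(CCCCCCc1ccccc1)N[C@H]1CCOC1=O`: > 100000 nM

Of the compounds shown here, three have been tested in a functional assay on NCI-H630 cells (Homo sapiens) for cytotoxicity, read by sulforhodamine B assay, with a stated time of 5 days; on this read-out higher numbers stand for weaker inhibition and lower numbers for stronger inhibition. Compound 1 gives a value that is a limit of the assay, > 100000 nM. Compound 3 likewise gives only a limit, > 100000 nM. Among the measured compounds shown here, compound 2 is the one compound that gives a number, 16000 nM. The difference between the core of compound 2 and the core of compound 3 is not broken down here.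

Compound 3 and compound 1 differ by phenyl in place of benzyl on a saturated chain carbon, five bonds along the chain from a carbonyl carbon. The step that the two limits leave unreadable from compound 3 to compound 1 cannot be read, since both values sit at the limit described by the limit of > 100000 nM in this assay, at which 2 of the 3 values shown sit.

Compound 4, `O=C(CCCCCCCCc1ccccc1)CC(=O)N[C@H]1CCOC1=O`, is not yet measured. It differs from compound 2 by phenyl in place of benzyl on a saturated chain carbon, eight bonds along the chain from a carbonyl carbon. This is the same kind of change as that from compound 3 to compound 1, though the place is not the same: there it sits five bonds along the chain from a carbonyl carbon, here eight bonds along the chain from a carbonyl carbon. Because the earlier step that the two limits leave unreadable from compound 3 to compound 1 gives no readable size, the expectation for compound 4 rests on compound 2 alone, with the loss of one chain carbon expected to weaken the read-out somewhat, so the step from compound 2 to compound 4 is estimated at a 1.9-fold higher number from compound 2 to compound 4 (0.27 log units; within the scatter). Compound 4 is therefore expected to give about 30000 nM in this assay, most likely between 10000 nM and 100000 nM.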

Compound 4, half-maximal inhibitory concentration: 11000 nM
Estimate against measurement, compound 4: 2.7-fold (0.44 log units) above, within the range that was stated.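

In this assay, putting phenyl in place of benzyl on a saturated chain carbon, eight bonds along the chain from a carbonyl carbon, gives a 1.5-fold lower number from compound 2 to compound 4 (0.16 log units; within the scatter), so on this core the change leaves the two values indistinguishable from repeat measurements. The same kind of change at the other place, five bonds along the chain from a carbonyl carbon on the core of compound 3, cannot be read, because compound 3 and compound 1 both give only a limit of the assay: the limit of > 100000 nM in this assay, at which 2 of the 4 values shown sit. The series therefore offers a single readable instance of this change, which shows that it is tolerated on one core but does not show that the result carries over to the other core, where no size can be compared.

The compounds shown leave open whether a longer chain on the core of compound 3 would lift its values off the limit and make the step readable there. They also leave open how the read-out on the core of compound 2 would respond to a chain longer than that of compound 2, or to an amine or a carboxylic acid at the chain end in place of phenyl.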